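The source may hold more compounds than are shown below. What is called first, only, known or untested is meant among the compounds shown, and "the series" means these compounds.

Compound 3 `CCc1ccc2[nH]c(=O)c(CN(Cc3ccc(C(C)(C)C)cc3)[C@@H](C)c3ccc(OC)cc3)cc2c1` carries a 1-(4-methoxyphenyl)ethyl group on the amine nitrogen of the shared core. In a toxicity assay on MDCK cells (Canis lupus familiaris) for cytotoxicity, read by crystal violet staining, with a stated time of 48 h (on this read-out higher numbers stand for lower toxicity in this test and lower numbers for higher toxicity in this test), compound 3 gives only a limit, > 5000 nM. Compound 2 `CCc1ccc2[nH]c(=O)c(CN(Cc3ccc(C(C)(C)C)cc3)[C@@H](C)c3ccc(F)cc3)cc2c1` likewise gives only a limit, > 5000 nM. Compound 1 `CCc1ccc2[nH]c(=O)c(CN(Cc3ccc(F)cc3)Cc3ccc(C(C)(C)C)cc3)cc2c1` also gives only a limit, > 33000 nM. Thus the limit of > 33000 nM in this assay, at which 1 of the 3 values shown sits, and the limit of > 5000 nM in this assay, at which 2 of the 3 values shown sit, account for every value shown, and the steps a step that the two limits leave unreadable from compound 1 to compound 3 and a step that the two limits leave unreadable from compound 2 to compound 3 carry no readable size. Compound 4 `CCc1ccc2[nH]c(=O)c(CN(Cc3ccc(C(C)(C)C)cc3)C(C)c3ccc(OC(F)F)cc3)cc2c1` differs from compound 3 by 1-(4-(difluoromethoxy)phenyl)ethyl in place of 1-(4-methoxyphenyl)ethyl on an amine nitrogen. For the measured compounds named here, with no measured step readable, the scatter alone frames the expectation. Compound 4 is expected to give 8000 nM, between 4000 nM and 30000 nM, most probably again as a limit. That expectation corresponds to a step that the limit leaves unreadable from compound 3 to compound 4, none beyond the scatter.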

Compound 4, half-maximal cytotoxic concentration: > 5000 nM
Compound 4 gave a limit, no number; the forecaster's own chance of this, stated with the estimate: 85%; the middle value is on the limit's open side.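

Compound 4, like compounds 1, 2 and 3, gives only a limit in this assay, so none of its steps from those compounds can be read. The compounds shown leave open whether the groups on the amine nitrogen change the half-maximal cytotoxic concentration at all.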